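Diacylhydrazine series: from compound 3 to compound 4

The source may report more compounds than this note shows. Statements on the series, on what has been measured and on what is new or still open speak of the compounds shown alone.

Measured so far:
In an assay on cells for agonist activity at ecdysone receptor (Bombyx mori), read by a luciferase reporter, with a stated time of 24 h (a lower number here means that less compound is needed, a higher number that more compound is needed for the effect), compound 1 `CC(C)(C)N(NC(=O)c1ccccc1Cl)C(=O)c1ccccc1Cl` gives 331 nM.
In this assay compound 2 `CC(C)(C)N(NC(=O)c1cccc(Br)c1)C(=O)c1ccccc1Cl` gives 191 nM.
In this assay compound 3 `CC(C)(C)N(NC(=O)c1ccc(Br)cc1)C(=O)c1ccccc1Cl` gives 33.9 nM.

Compound 3 has the lowest number of the three; the next is compound 2, a step away that is beyond the scatter, and compound 1 lies furthest. The steps of a 9.8-fold lower number from compound 1 to compound 3 (0.99 log units; beyond the scatter) and a 5.6-fold lower number from compound 2 to compound 3 (0.75 log units; beyond the scatter) both point to 4-bromophenyl on the carbonyl carbon as the ring that gives the lowest number, while a 1.7-fold lower number from compound 1 to compound 2 (0.24 log units; within the scatter) lies within the scatter.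

Compound 4 `Cc1ccc(C)c(C(=O)NN(C(=O)c2ccccc2Cl)C(C)(C)C)c1` is not yet measured in this assay. Its change from compound 3: 2,5-dimethylphenyl in place of 4-bromophenyl on a carbonyl carbon. Within the data shown here, no measured step covers a methyl-bearing ring, so the bearing steps are indirect: in every case seen so far, a ring other than 4-bromophenyl on that carbonyl carbon gave a higher number, and 2,5-dimethylphenyl is such a ring. A rise in the number is therefore expected for compound 4, with wide uncertainty, as the estimated step of a 4.4-fold higher number from compound 3 to compound 4 (0.65 log units; beyond the scatter). Compound 4 is expected to give about 150 nM, within 40 nM to 600 nM.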

Compound 4, half-maximal effective concentration: 1620 nM
Compound 4: the middle estimate sits 11-fold (1.03 log units) below what was measured; measured number outside the range, above it.
By their numbers in this assay, from the lowest: compound 3; then compounds 2 and 1 (each within the scatter of the next); then compound 4.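

In this assay the 2,5-dimethylphenyl ring on the carbonyl carbon gives the highest number of the four, with a 48-fold higher number from compound 3 to compound 4 (1.68 log units; beyond the scatter) and an 8.5-fold higher number from compound 2 to compound 4 (0.93 log units; beyond the scatter) and a 4.9-fold higher number from compound 1 to compound 4 (0.69 log units; beyond the scatter) all on the same side. The earlier compounds shown here showed only how far the number falls among halogen-bearing rings at this position, whereas this change shows that the number can also rise well past that of compound 1 when the ring carries only carbon. Nothing at hand gives a reason for this rise.

Compound 4 differs from the others in both the kind and the placing of its ring groups, so the two effects remain unseparated. As far as these compounds go, whether a 4-methylphenyl ring would track compound 3 or compound 4 stays open, as does the outcome for a 4-methoxyphenyl or 4-aminophenyl ring on that carbonyl carbon.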